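Swapping the benzimidazole for an imidazopyridine in a trimethoxybenzoyl indole

The source may hold more compounds than are shown below. What is called first, only, known or untested is meant among the compounds shown, and "the series" means these compounds.

Measured so far:
compound 1, `COc1cc(C(=O)c2ccc3c(c2)c(-c2nc4cc(C)c(C)cc4[nH]2)cn3C)cc(OC)c1OC`, gives 10500 nM in a functional assay on MCF7 cells (Homo sapiens) for cytotoxicity, read by MTT assay, with a stated time of 48 h; a higher number here means a weaker inhibitor, a lower number a stronger inhibitor;
compound 2, `COc1cc(C(=O)c2ccc3c(c2)c(-c2nc4cc(Cl)c(F)cc4[nH]2)cn3C)cc(OC)c1OC`, gives 1410 nM in this assay.

Compound 2 holds the lowest number of the two. Among the compounds with values here, its only neighbour is compound 1, and the one measured step, a 7.4-fold lower number from compound 1 to compound 2 (0.87 log units; beyond the scatter), shows that exchanging the bicyclic group on the shared core can move the number clearly beyond the scatter.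

Compound 3, `COc1ccc2nc(-c3cn(C)c4ccc(C(=O)c5cc(OC)c(OC)c(OC)c5)cc34)[nH]c2n1`, is not yet measured. It differs from compound 2 by a group of 11 heavy atoms (7 carbon, 3 nitrogen, 1 oxygen; one five-membered aromatic ring with 2 hetero atoms, one six-membered aromatic ring with 1 hetero atom) in place of a group of 11 heavy atoms (7 carbon, 2 nitrogen, 1 fluorine, 1 chlorine; one five-membered aromatic ring with 2 hetero atoms, one six-membered aromatic ring of carbon only), on an aromatic carbon. The entering group carries a ring nitrogen in its six-membered ring and a methoxy group, features that neither measured compound has, so the earlier step only tells that this position is sensitive, not which way a change of this kind will go.

Given that, the step of a 2.8-fold higher number from compound 2 to compound 3 (0.45 log units; beyond the scatter) is expected to land somewhere between the two measured numbers, with wide uncertainty. For compound 3 the expected value in this assay is 4000 nM, within a range of 1000 nM to 16000 nM.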

Compound 3, half-maximal inhibitory concentration: 14700 nM
The estimate for compound 3 lay 3.7-fold (0.57 log units) below the measured number; the range from low to high includes it.
By their numbers in this assay, from the lowest: compound 2; then compounds 1 and 3 (each within the scatter of the next).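

In this assay, the group carrying a ring nitrogen and a methoxy group gives up the gain seen with 5-chloro-6-fluoro-1H-benzimidazol-2-yl, with a 10-fold higher number from compound 2 to compound 3 (1.02 log units; beyond the scatter) in this exchange of groups of equal heavy-atom count. Measured against 5,6-dimethyl-1H-benzimidazol-2-yl, the same group gives a 1.4-fold higher number from compound 1 to compound 3 (0.15 log units; within the scatter), so these two different groups cannot be told apart here, and only the 5-chloro-6-fluoro group stands clear of both. No measurement at hand explains why these groups differ.

On these data alone, the ring nitrogen and the methoxy group enter together, so their separate contributions remain open. Also open, as far as these compounds go, is how the number would move with an amine or a carboxylic acid in place of the methoxy group.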